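The compounds below may be only part of what the source reports. "The series", "measured", "known", "first", "only" and "open" are said of these compounds alone.

Measured so far:
compound 1 `CCOC(=O)c1c(C)oc2ncnc(Nc3ccc(OCc4ccc(C)cc4)cc3)c12` — > 1000000 nM
compound 2 `CCOC(=O)c1c(C)oc2ncnc(Nc3ccc(OCc4ccccc4)cc3)c12` — > 1000000 nM
compound 3 `Cc1cccc(Nc2ncnc3oc(C)c(C(=O)O)c23)c1` — 100000 nM

In a functional assay on A549 cells (Homo sapiens) for cytotoxicity, read by MTT assay, with a stated time of 72 h (on this read-out lower numbers stand for stronger inhibition and higher numbers for weaker inhibition), compound 1 reports only a limit, > 1000000 nM. Compound 2 likewise reports only a limit in this assay, > 1000000 nM. The change between them, (hydrogen in place of methyl on an aromatic carbon), gives a step that the two limits leave unreadable from compound 1 to compound 2; both values sit at the limit of > 1000000 nM in this assay, at which 2 of the 3 values shown sit, so the step cannot be sized. Among the measured compounds shown here, compound 3 is the one number in the set: in this assay compound 3 gives 100000 nM. How the core of compound 3 differs from the core of compound 1 is not broken down here.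

Compound 4 `Cc1oc2ncnc(Nc3ccccc3)c2c1C(=O)O` is not yet measured. It differs from compound 3 by hydrogen in place of methyl on an aromatic carbon, the same kind of change as from compound 1 to compound 2, though the place differs: there the methyl sat para to a large group, here it sits meta to a large group. For the measured compounds named here, the only measured instance of this change is unreadable, so no size can be carried over.

The step from compound 3 to compound 4 in this assay is expected to be small, a 1.5-fold higher number from compound 3 to compound 4 (0.18 log units; within the scatter), resting on the value of compound 3, 100000 nM, as the nearest measured point. Compound 4 is estimated at 150000 nM, between 40000 nM and 600000 nM.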

Compound 4, half-maximal inhibitory concentration: 191000 nM
The estimate for compound 4 lay 1.3-fold (0.10 log units) below the measured number; measured number inside the range.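

In this assay, going from 3-methylphenyl to phenyl on the core of compound 3 gives a 1.9-fold higher number from compound 3 to compound 4 (0.28 log units; within the scatter), so compound 3 and compound 4 cannot be told apart on this read-out. Among the compounds shown here, compound 1 and compound 2 each report only a limit, so the one other instance of this change cannot be read: the limit of > 1000000 nM in this assay, at which 2 of the 4 values shown sit. The series therefore holds a single readable instance of hydrogen in place of methyl, on one core and at one place on the ring, and it shows neither that the change carries over to the core of compound 1 nor that it fails to.

Open, from the compounds shown here alone, is whether an amine, a chlorine or a longer chain at the place of that methyl would separate from compound 3 at 100000 nM. Also open, going by these compounds, is whether 3-methylphenyl and phenyl on the core of compound 1 would give numbers that allow the two cores to be compared.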